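Swapping the Pyrazole Attachment in an Adrenergic Agonist Core

This account rests on a few compounds, and the source may have more. Where it says the series, first, only, none or still open, it means among the compounds named here.

Compound 1 `c1cc(-c2cn[nH]c2)c2c(c1)C(c1ncc[nH]1)CC2` gives 84% in a functional assay on CHO cells for agonist activity at Alpha-1A adrenergic receptor (Homo sapiens), read by FLIPR and calcium flux; a higher number here means a larger maximal response, a lower number a smaller maximal response.
Compound 2 `Cc1n[nH]cc1-c1cccc2c1CCC2c1ncc[nH]1` gives 91% in this assay.

Compound 1 stands lowest of the two numbers measured, and its nearest neighbour is compound 2, reached by a number 7 percentage points higher from compound 1 to compound 2 (within the scatter), a methyl in place of hydrogen on an aromatic carbon. Compound 3 `Cn1ccc(-c2cccc3c2CCC3c2ncc[nH]2)n1` has not yet been measured in this assay. It differs from compound 1 as follows: 1-methyl-1H-pyrazol-3-yl in place of 1H-pyrazol-4-yl on an aromatic carbon. Going by the values given here, the only measured step, from compound 1 to compound 2, touches the same ring but keeps the hydrogen-bond donor and the point of attachment, so it bears only loosely on the present change; its size is within the scatter. Among the compounds with values here, no measured step covers the loss of the donor or the shift of the attachment, so the direction of the step in this assay is open, and no step beyond the scatter is expected with confidence. Compound 3 is therefore estimated at 80% in this assay, within a range from 50% to 105%. That estimate means a step of a number 4 percentage points lower from compound 1 to compound 3 (within the scatter), which is expected to be small.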

Compound 3, largest response reached (Emax), in percent of the reference or control that the assay uses: 19%
Beside the measured number, compound 3's estimate is 61 percentage points above it; measured number below the stated range.
By their numbers in this assay, from the lowest: compound 3; then compounds 1 and 2 (each within the scatter of the next).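

In this assay this aromatic carbon of the shared core proves sensitive to the group it carries, which the earlier pair did not show, since a methyl on the pyrazole of compound 2 left the maximal response within the scatter of compound 1. Placing 1-methyl-1H-pyrazol-3-yl there instead of 1H-pyrazol-4-yl gives a number 65 percentage points lower from compound 1 to compound 3 (beyond the scatter), and placing it there instead of 3-methyl-1H-pyrazol-4-yl gives a number 72 percentage points lower from compound 2 to compound 3 (beyond the scatter), so both steps from the compounds with a free pyrazole hydrogen-bond donor are large, and the group that enters has 0 hydrogen-bond donors where the group that leaves has 1. No measurement is available that explains this fall in the response.

The exchange alters the point of attachment, the methyl on the ring nitrogen and the donor count together, so the compounds shown cannot say which of these carries the step. They also leave open how 1H-pyrazol-3-yl, 1-methyl-1H-pyrazol-4-yl or a simple amine at this carbon would compare.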